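This account rests on a few compounds, and the source may have more. Where it says the series, first, only, none or still open, it means among the compounds named here.

Measured so far in a functional assay on NCI-H460 cells (Homo sapiens) for inhibition, read by MTT assay, with a stated time of 24 h, tested at 100 ug/mL; on this read-out lower numbers stand for less inhibition of growth and higher numbers for more inhibition of growth at the one concentration tested
compound 1 `O=C(O)CCCCC(CCSC(=O)c1ccccc1)SC(=O)c1ccccc1` gives 72.8%
compound 2 `CC(=O)SCCC(CCCCC(=O)Nc1ccc(Cl)cc1)SC(C)=O` gives 47.3%

Compound 1 holds the higher of the two values, and its gap to compound 2 lies beyond the scatter. The step followed here leads to compound 3 `O=C(CCCCC(CCSC(=O)c1ccccc1)SC(=O)c1ccccc1)Nc1ccccc1Cl` and is counted as (2-chlorophenyl)amino in place of hydroxy on a carbonyl carbon, so carboxy becomes (2-chlorophenyl)carbamoyl. Among the measured compounds shown here, no measured pair differs in one place only, so no direct step exists for this change. Compound 2 at 47.3% also has an amide at that carbonyl, but it differs elsewhere too and offers only weak guidance. A fall somewhat beyond the scatter is expected in this assay and the estimated size is a number 17.8 percentage points lower from compound 1 to compound 3 (beyond the scatter) for this change. The expected value for compound 3 is 55% with an estimated range (33% to 78%).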

Compound 3, percent growth inhibition at one concentration: "not active" (no number reported)
Compound 3 has no reported number here; no gap can be computed for the estimate.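

Among the compounds shown here, compound 3 is reported as "not active" without a number in this assay, and no step from compound 1 to compound 3 can be read. Nothing available bears on a cause for this result. The compounds shown leave open how other carbamoyl groups on the core of compound 1 would read out.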